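The source may hold more compounds than are shown below. What is called first, only, known or untested is meant among the compounds shown, and "the series" means these compounds.

Compound 1 `CCN(CC)c1cc2[nH]c(C3CCCCC3)nc2cc1NC(=O)c1cccc(Br)c1`: > 100 ug/mL
Compound 2 `CCCc1ccc(C(=O)Nc2cc3nc(C4CCCCC4)[nH]c3cc2N(CC)CC)cc1`: "not determined" (no result reported)

In an ADME assay on Vero cells (Chlorocebus sabaeus) for cytotoxicity, read by resazurin assay, with a stated time of 3 days (on this read-out higher numbers stand for weaker inhibition and lower numbers for stronger inhibition), compound 1 gives > 100 ug/mL, which is a limit of the assay rather than a number. For compound 2 in this assay the result is "not determined" (no result reported), so compound 2 stands nowhere on the numbers shown. Going by the values given here, the only other value shown is the one for compound 1. Compound 3 `CCN(CC)c1cc2[nH]c(C3CCCCC3)nc2cc1NC(=O)c1ccc(Br)cc1` differs from compound 2 by bromo in place of propyl on an aromatic carbon. With no step between measured compounds shown, the size and direction of this step in this assay cannot be judged from the data. Compound 3 is estimated at about 100 ug/mL, between 50 ug/mL and 200 ug/mL, since compound 1 already sits at the limit of > 100 ug/mL in this assay, at which 1 of the 2 values shown sits.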

Compound 3, half-maximal inhibitory concentration: > 100 ug/mL
Compound 3: a limit, no number (the forecaster's own chance of this, stated with the estimate: 70%); the middle value sits exactly at the limit.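

In this assay, going by these compounds alone, compound 1 and compound 3 both stop at a limit, not a number, so no step between them can be read. Open remains whether 3-bromophenyl and 4-bromophenyl differ at all, and how 4-propylphenyl compares with 4-bromophenyl.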